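Chloro Step Repeated on a Second Core

A few compounds are considered here, and "the series" means these few. Any claim that something is new, unique, unknown or untested is made for them only; others in the source may bear on it.

Compound 1 `Cn1c(SCC(=O)Nn2c(COc3ccc(Cl)cc3Cl)nc3ccccc3c2=O)nc(-c2ccccc2)c(C#N)c1=O` was tested in a functional assay on the whole organism (strain albino) for inhibition, with Rattus norvegicus as the target, read by paw edema, with stated times of 1 h and 3 h, at a dose of 100 mg/kg by the oral route (on this read-out higher numbers stand for a stronger effect at the one dose given and lower numbers for a weaker effect), and compound 1 gives 59.7%. Compound 2 `Cn1c(SCC(=O)Nn2c(COc3ccc(Cl)cc3Cl)nc3ccccc3c2=O)nc(-c2ccc(Cl)cc2)c(C#N)c1=O` differs from compound 1 by a single change, (chloro in place of hydrogen on an aromatic carbon), and in this assay compound 2 gives 73.7%. That one change produced a number 14 percentage points higher from compound 1 to compound 2 (beyond the scatter). Compound 3 `N#Cc1c(Cl)nc(SCC(=O)Nn2c(COc3ccc(Cl)cc3Cl)nc3ccccc3c2=O)nc1-c1ccccc1` is built on a different core; the difference between the two cores is not broken down here. In this assay compound 3 gives 68.4%, a number that lies within the usual scatter of both of the other measured values. Compound 4 `N#Cc1c(Cl)nc(SCC(=O)Nn2c(COc3ccc(Cl)cc3Cl)nc3ccccc3c2=O)nc1-c1ccc(Cl)cc1` has not yet been measured. Going by the values given here, it differs from compound 3 by chloro in place of hydrogen on an aromatic carbon, the same change as the one from compound 1 to compound 2, at the same kind of place. Because the first such change gave a number 14 percentage points higher from compound 1 to compound 2 (beyond the scatter), a step in the same direction, though possibly smaller, is expected for compound 4, estimated as a number 8.6 percentage points higher from compound 3 to compound 4 (within the scatter). Compound 4 is therefore expected to give about 77%, most likely between 66% and 88%.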

Compound 4, a percentage reported as inhibition, in the whole organism at one dose (the size of the read-out at that dose, not a potency): 68.4%
The estimate for compound 4 lay 8.6 percentage points above the measured number; measured number inside the range.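

In this assay, putting chloro in place of hydrogen on the phenyl ring of compound 3 gave no change at the digits printed from compound 3 to compound 4 (within the scatter). Set beside the same change on the core of compound 1, the two results cannot be told apart: the same change on two cores in this assay, a number 14 percentage points higher (beyond the scatter) from compound 1 to compound 2 and no change at the digits printed (within the scatter) from compound 3 to compound 4, 14 percentage points apart, within the scatter of two such steps. The clear rise seen on the first core did not show up as a clear rise on the second, yet the gap between the steps is too small to show that the two cores really respond differently, so with a single pair on each core these data neither confirm nor rule out that the change carries over.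

Going by these compounds, only hydrogen and chloro appear at this place on the phenyl ring, so it remains open how a fluoro or a methoxy group there would behave on either core. Also open, on these data alone, is what would happen if the chloro on the core of compound 3 gave way to an amine.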